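The compounds below may be only part of what the source reports. "The series", "measured", "known", "first", "only" and "open" are said of these compounds alone.

Compound 2 `CCn1cc(C(=O)N2N=C(c3cc4ccccc4o3)CC2c2ccccc2OC)c(=O)c2ccc(C)nc21` is one of two measured members of this small series. In an ADME assay on Vero cells (Chlorocebus sabaeus) for cytotoxicity, read by MTT assay, with a stated time of 72 h (a lower number here means a stronger inhibitor, a higher number a weaker inhibitor), compound 2 gives only a limit, > 187000 nM. Compound 1 `CCn1cc(C(=O)N2N=C(c3cc4ccccc4o3)CC2c2ccccc2O)c(=O)c2ccc(C)nc21` likewise gives only a limit in this assay, > 157000 nM. The step that the two limits leave unreadable from compound 1 to compound 2 therefore cannot be sized. Compound 3 `CCn1cc(C(=O)N2N=C(c3cc4ccccc4o3)CC2c2ccc(N(C)C)cc2)c(=O)c2ccc(C)nc21` differs from compound 2 by 4-(dimethylamino)phenyl in place of 2-methoxyphenyl on a saturated ring carbon. Among the measured compounds shown here, no measured step bears on this change, so an at least 1.2-fold lower number from compound 2 to compound 3 (0.09 log units; that floor lies within the scatter) is expected to be no step beyond the scatter. Compound 3 is estimated at 150000 nM, from 50000 nM to 300000 nM, and is likely to be reported again only as a limit.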

Compound 3, half-maximal inhibitory concentration: > 206000 nM
Compound 3 gave a limit, no number; the forecaster's own chance of this, stated with the estimate: 70%; middle value at least 1.3-fold (0.13 log units) from the limit.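

Among the compounds shown here, compound 1, compound 2 and compound 3 each give only a limit in this assay, so no step among them can be read. As far as these compounds go, how far their true values lie apart remains open.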